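This account rests on a few compounds, and the source may have more. Where it says the series, first, only, none or still open, it means among the compounds named here.

Measured compounds:
- compound 1, `Cc1ccc(S(=O)(=O)N(Cc2nnc(Cc3ccc(N(C)C)cc3)o2)c2cccc(Cl)c2C)cc1`: 12.6 nM
- compound 2, `Cc1ccc(S(=O)(=O)N(Cc2nnc(Cc3ccc(F)cc3)o2)c2cccc(Cl)c2C)cc1`: 200 nM

Compound 2 stands at the higher of the two numbers in an assay on CHO cells for displacement of a labelled ligand from prostaglandin E2 receptor EP1 subtype (Homo sapiens); a lower number here means a stronger inhibitor, a higher number a weaker inhibitor; its nearest neighbour is compound 1, and the step of a 16-fold higher number from compound 1 to compound 2 (1.20 log units; beyond the scatter) separates them. Compound 3, `Cc1ccc(S(=O)(=O)N(Cc2nnc(Cc3cccc(F)c3)o2)c2cccc(Cl)c2C)cc1`, has not been measured. It differs from compound 2 in one place: 3-fluorophenyl in place of 4-fluorophenyl on a saturated chain carbon bound to an aromatic carbon; the same difference, cut one bond further out, reads 4-fluorobenzyl to 3-fluorobenzyl.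

Within the data shown here, no measured step bears on this change directly. Among the measured compounds shown here, the only step recorded, a 16-fold higher number from compound 1 to compound 2 (1.20 log units; beyond the scatter), exchanges one group for another at the same site and says nothing about shifting the fluorine around the ring. For the measured compounds named here, for a pair with the same atoms joined differently, with no neighbouring example to lean on, the expected step in this assay from compound 2 to compound 3 is no change at the digits printed from compound 2 to compound 3 (within the scatter), a change not expected to exceed the scatter in either direction. The estimate for compound 3 is therefore 200 nM, with a range from 70 nM to 600 nM, and the measured value will decide.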

Compound 3, half-maximal inhibitory concentration: 316 nM
For compound 3 the middle estimate is 1.6-fold (0.20 log units) below the measured one; low and high end bracket the measured number.
By their numbers in this assay, from the lowest: compound 1; then compounds 2 and 3 (each within the scatter of the next).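

In this assay, the place of the fluorine on the phenyl group makes no difference that this assay can resolve: 3-fluorophenyl in place of 4-fluorophenyl gives a 1.6-fold higher number from compound 2 to compound 3 (0.20 log units; within the scatter). The gap to compound 1 therefore does not hang on one particular fluorine placement, since 3-fluorophenyl in place of 4-(dimethylamino)phenyl gives a 25-fold higher number from compound 1 to compound 3 (1.40 log units; beyond the scatter), and compound 1 stands as the strongest inhibitor of the three, with neither fluorinated compound going against that. Nothing available explains either the large gap or the lack of a resolved difference between the two fluorinated compounds.

The compounds shown leave open whether the advantage of compound 1 belongs to the dimethylamino group specifically or would also appear with a primary amine, a methoxy group or a carboxylic acid on the phenyl group, and how an unsubstituted phenyl group would compare with all of them. They also leave open whether 3-(dimethylamino)phenyl would match 4-(dimethylamino)phenyl, which would show whether the indifference to placement seen with fluorine extends to the amine.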